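The source may hold more compounds than are shown below. What is called first, only, known or untested is meant among the compounds shown, and "the series" means these compounds.

Of the compounds shown here, two built on one shared core have been read in a functional assay on IMR-32 cells (Homo sapiens) for cytotoxicity, read by sulforhodamine B assay, with a stated time of 48 h; on this read-out higher numbers stand for weaker inhibition and lower numbers for stronger inhibition. Compound 1 (`C=CCOc1ccc(F)cc1C(=O)c1cccnc1`) gives 91000 nM, and compound 2 (`C=CCOc1ccc(Br)cc1C(=O)c1cccnc1`), with bromo in place of fluoro on an aromatic carbon, gives 88000 nM. Within the data shown here, these two numbers lie within the scatter of each other, so compound 2 stands level with its only neighbour and the pair cannot be ranked. Still unmeasured is compound 3 (`C=CCOc1ccc(C)cc1C(=O)c1cccnc1`), which differs from compound 2 in one place: methyl in place of bromo on an aromatic carbon. In words, this is methyl in place of bromo on an aromatic carbon, para to an allyloxy group. Among the measured compounds shown here, one measured step bears on this carbon, a 1.0-fold lower number from compound 1 to compound 2 (0.01 log units; within the scatter), and it stays within the scatter. Methyl itself has not been tested there, and a single step is a thin basis, but nothing measured so far points to a shift in this assay. No change beyond the scatter is therefore expected. The step expected is a 1.0-fold lower number from compound 2 to compound 3 (0.02 log units; within the scatter). Compound 3 is estimated at 85000 nM, with an expected range from 45000 nM to 150000 nM.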

Compound 3, half-maximal inhibitory concentration: 87000 nM
The estimate for compound 3 lay 1.0-fold (0.01 log units) below the measured number, within the range that was stated.
By their numbers in this assay, from the lowest: compounds 3, 2 and 1 (each within the scatter of the next).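

In this assay, the carbon para to an allyloxy group has now been read with a non-halogen group: methyl in place of bromo gives a 1.0-fold lower number from compound 2 to compound 3 (0.00 log units; within the scatter), and methyl in place of fluoro gives a 1.0-fold lower number from compound 1 to compound 3 (0.02 log units; within the scatter). Where the earlier pair showed only that one halogen could stand in for another without a shift beyond the scatter, compounds 1, 2 and 3 now stand level across fluoro, bromo and methyl, so on these three compounds the read-out does not separate the groups at this carbon. Nothing at hand offers an explanation for this level read-out.

On these data alone, all three groups are small, so what an amine, a carboxylic acid or a longer chain on this carbon would do to the number remains open. As far as these compounds go, all three compounds also share the allyloxy group and the rest of the core, so it is equally open whether an exchange elsewhere, such as a methoxy group in place of the allyloxy group, would move the number in this assay.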